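Methylsulfanyl for trifluoromethyl on the thiourea aryl group

The compounds below may be only part of what the source reports. "The series", "measured", "known", "first", "only" and "open" are said of these compounds alone.

Measured so far:
compound 1 `NC(=O)c1c(NC(=O)c2ccccc2Cl)sc2c1CCN(Cc1cc(Cl)cc(Cl)c1)C2`: 19600 nM
compound 2 `NC(=O)c1c(NC(=O)c2ccccc2Cl)sc2c1CCN(C(=S)Nc1ccccc1F)C2`: 28700 nM
compound 3 `NC(=O)c1c(NC(=O)c2ccccc2Cl)sc2c1CCN(C(=S)Nc1ccccc1C(F)(F)F)C2`: 26700 nM

In a functional assay on HeLa cells (Homo sapiens) for antiproliferative activity, with a stated time of 24 h (a lower number here means a stronger inhibitor, a higher number a weaker inhibitor), compound 3 gives 26700 nM, the second highest of the three numbers; its gap to compound 2 and its gap to compound 1 are both within the scatter, so the three compounds are not separated by this assay.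

Compound 4 `CSc1ccccc1NC(=S)N1CCc2c(sc(NC(=O)c3ccccc3Cl)c2C(N)=O)C1` differs from compound 3 by methylsulfanyl in place of trifluoromethyl on an aromatic carbon. Among the measured compounds shown here, two steps bear on this: a 1.5-fold higher number from compound 1 to compound 2 (0.17 log units; within the scatter) and a 1.1-fold lower number from compound 2 to compound 3 (0.03 log units; within the scatter). Neither exchange on the amine nitrogen or on the aryl ring moved the number beyond the scatter, so for compound 4 the expected step is a 1.1-fold lower number from compound 3 to compound 4 (0.03 log units; within the scatter), that is no change beyond the scatter in this assay.

Compound 4 is estimated at 25000 nM, with a range of 10000 nM to 60000 nM.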

Compound 4, half-maximal inhibitory concentration: 43600 nM
Beside the measured number, compound 4's estimate is 1.7-fold (0.24 log units) below it; the measured number falls inside the stated range.
By their numbers in this assay, from the lowest: compounds 1, 3, 2 and 4 (each within the scatter of the next, the first and the last beyond it).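

In this assay methylsulfanyl for trifluoromethyl on this aromatic carbon gives a 1.6-fold higher number from compound 3 to compound 4 (0.21 log units; within the scatter) and methylsulfanyl for fluoro gives a 1.5-fold higher number from compound 2 to compound 4 (0.18 log units; within the scatter) so the three groups seen here stay unseparated. Among the compounds shown here, exchanging the whole group on the ring amine nitrogen gives a 2.2-fold higher number from compound 1 to compound 4 (0.35 log units; beyond the scatter) as the first step beyond the scatter, and a modest one. Nothing available accounts for this step.

An amine or a carboxylic acid on this aromatic carbon could show whether the position responds at all. Going by these compounds, whether any group here brings the number clearly below those seen so far also remains open.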